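The source may hold more compounds than are shown below. What is called first, only, known or untested is meant among the compounds shown, and "the series" means these compounds.

Measured so far in an assay on cells for inhibition of cytochrome P450 11B1, mitochondrial (Homo sapiens); on this read-out higher numbers stand for weaker inhibition and lower numbers for stronger inhibition:

compound 2 `CC(C)CC1n2cncc2CN(Cc2ccccc2)S1(=O)=O`: 103 nM
compound 1 `CC(C)CC1n2cncc2CN(Cc2ccc(OC(F)(F)F)cc2)S1(=O)=O`: 544 nM

Among the measured compounds shown here, compound 2 holds the lower of the two numbers in this assay; compound 1 is the only neighbour, and the step of a 5.3-fold lower number from compound 1 to compound 2 (0.72 log units; beyond the scatter) lies beyond the scatter, so the two are genuinely separated.

Compound 3 `CC(C)CC1n2cncc2CN(Cc2ccc(F)cc2)S1(=O)=O` is compound 2 with fluoro in place of hydrogen on an aromatic carbon. For the measured compounds named here, the aromatic carbon that carries the fluoro of compound 3 carries the trifluoromethoxy of compound 1, so the one step that bears on this change is a 5.3-fold lower number from compound 1 to compound 2 (0.72 log units; beyond the scatter), where a substituent at that carbon raised the number. Fluoro brings one heavy atom where trifluoromethoxy brought several, and no step with fluoro itself is available, so the size of its effect cannot be read from the data. The expectation is a small shift toward higher numbers, at or near the edge of the scatter, and clearly short of the step seen with compound 1. For compound 3 the estimated step is a 1.5-fold higher number from compound 2 to compound 3 (0.16 log units; within the scatter). Compound 3 is therefore expected near 150 nM, within 60 nM to 380 nM in this assay.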

Compound 3, half-maximal inhibitory concentration: 26.1 nM
The estimate for compound 3 lay 5.7-fold (0.76 log units) above the measured number, and the stated range ends above it.
By their numbers in this assay, from the lowest: compound 3; then compound 2; then compound 1.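

The carbon para to a large group does not respond to substitution in one direction only: in this assay, the change from phenyl to 4-fluorophenyl gives a 3.9-fold lower number from compound 2 to compound 3 (0.60 log units; beyond the scatter), whereas the earlier step, a 5.3-fold lower number from compound 1 to compound 2 (0.72 log units; beyond the scatter), had shown only that trifluoromethoxy carries the higher number compared with hydrogen. With hydrogen, fluoro and trifluoromethoxy now compared at this one carbon, the identity of the group decides the direction of the step, so the presence of a substituent alone does not set the outcome. The exchange of one group for the other at this carbon gives a 21-fold lower number from compound 1 to compound 3 (1.32 log units; beyond the scatter), the widest step in the set and the only one graded large, and nothing available here accounts for the difference between the two groups.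

Three groups at one carbon give no ranking for others, so chloro, methyl, methoxy or a nitrile at the same place could fall anywhere relative to these numbers. Also open, going by these compounds, is whether fluoro gives a step of similar size and direction on other aromatic carbons of this ring, or with a different chain in place of the one on the shared core.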